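Compound 2 and its analogue with a saturated chain

This account rests on a few compounds, and the source may have more. Where it says the series, first, only, none or still open, it means among the compounds named here.

Three compounds sharing one core are on record in an ADME assay on Vero cells (Chlorocebus sabaeus) for cytotoxicity, read by MTT assay, with a stated time of 72 h; on this read-out lower numbers stand for higher toxicity in this test and higher numbers for lower toxicity in this test. Compound 1 `CC(C)=CCCC1(C)C=Cc2c(ccc(C(=O)/C=C/c3ccc(O)c(C=O)c3)c2O)O1` carries the entry "not determined" (no result reported), and compound 3 `CC(C)=CCCC1(C)C=Cc2c(ccc(C(=O)/C=C/c3cc4cc(C)ccc4nc3Cl)c2O)O1` carries the entry "not determined" (no result reported). Among the measured compounds shown here, compound 2 `CC(C)=CCCC1(C)C=Cc2c(ccc(C(=O)/C=C/c3cccnc3)c2O)O1` gives 40700 nM, the only number available, so it cannot be ranked against the other two. Compound 4 `CC(C)CCCC1(C)C=Cc2c(ccc(C(=O)/C=C/c3cccnc3)c2O)O1`, not yet measured, differs from compound 2 in one place: isobutyl in place of 2-methylprop-1-en-1-yl on a saturated chain carbon, two bonds along the chain from a saturated ring carbon. The change is isobutyl in place of 2-methylprop-1-en-1-yl on a saturated chain carbon, two bonds along the chain from a saturated ring carbon. For the measured compounds named here, no measured pair shows what such a change does in this assay, so the expectation rests on compound 2 at 40700 nM alone. No shift beyond the usual scatter is expected in either direction, and the estimated 1.0-fold lower number from compound 2 to compound 4 (0.01 log units; within the scatter) stays within it. For compound 4 the estimated half-maximal cytotoxic concentration is 40000 nM, with an expected range from 16000 nM to 100000 nM.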

Compound 4, half-maximal cytotoxic concentration: 156000 nM
Compound 4: middle estimate off by 3.9-fold (0.59 log units), on the low side, outside the stated range (above it).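

In this assay, this position now has its first reading, and the change does register there (a 3.8-fold higher number from compound 2 to compound 4 (0.58 log units; beyond the scatter)), towards lower toxicity in this test. Among the compounds shown here, with only one number on record, the earlier compounds could not show whether this part of the chain affected the read-out at all, yet isobutyl and 2-methylprop-1-en-1-yl have the same count of heavy atoms and differ by the one double bond outside aromatic rings. No measurement given here bears on why the number moves.

A single pair leaves open whether the same change reads alike on compounds that differ elsewhere from compound 2 and compound 4. It also leaves open what a longer chain, a hydroxyl group or an amine at this place on the chain would do.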